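From 1H-pyrrol-2-yl to 1H-pyrazol-1-yl on a Shared Core

The compounds below may be only part of what the source reports. "The series", "measured", "known", "first", "only" and "open" are said of these compounds alone.

Within the data shown here, in a functional assay on PC-3 cells (Homo sapiens) for cytotoxicity, read by MTT assay, with a stated time of 72 h (on this read-out lower numbers stand for stronger inhibition and higher numbers for weaker inhibition), compound 2 `COc1ccc2[nH]c(-c3ccc[nH]3)cc2c1` gives 26000 nM and is the only compound with a true number so far. The other result offers no such anchor. For compound 1 `c1ccc2[nH]c(-n3cccn3)cc2c1` the result > 100000 nM is a limit of the assay and not a number.

The next compound to be tested, compound 3 `COc1ccc2[nH]c(-n3cccn3)cc2c1`, keeps the core of compound 2 but carries 1H-pyrazol-1-yl in place of 1H-pyrrol-2-yl on an aromatic carbon. Among the measured compounds shown here, no measured pair shows this swap by itself, so its size cannot be read directly from the data. One clue remains. Compound 1 also carries 1H-pyrazol-1-yl, and its limit of > 100000 nM points toward weaker inhibition for compound 3, although this is only an expectation. The estimated change is a 1.9-fold higher number from compound 2 to compound 3 (0.28 log units; within the scatter) in the direction of weaker inhibition, and it could be hard to separate from the scatter of this assay if the swap matters little. For compound 3 the expected value is 50000 nM with an estimated range of 15000 nM to 100000 nM as the likely span.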

Compound 3, half-maximal inhibitory concentration: > 100000 nM
Compound 3: a limit, no number; the forecaster's own chance of this, stated with the estimate: 40%; middle value at least 2.0-fold (0.30 log units) from the limit.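

In this assay, among these compounds, the swap of 1H-pyrrol-2-yl for 1H-pyrazol-1-yl on the shared core now has a readable size for the first time, with an at least 3.8-fold higher number from compound 2 to compound 3 (0.58 log units; beyond the scatter). This shows that the group on this aromatic carbon, next to the ring nitrogen, matters for the read-out, even though the two groups have the same number of heavy atoms; they differ in their hetero atoms and in their hydrogen-bond donors and acceptors, and a single pair cannot show which of these differences counts. The printed size is only the smallest the step can be because compound 3 gives a limit of the assay and not a number: the limit of > 100000 nM in this assay, at which 2 of the 3 values shown sit.

Going by these compounds, compound 1 and compound 3 both stand at limits, so the step that adds methoxy cannot be read and the contribution of that group remains unknown. On these data alone, it also remains open whether an amine or a phenyl ring at this place would match or improve on compound 2, with its 26000 nM.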